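Bromo to chloro on the six-membered aromatic ring

The source may hold more compounds than are shown below. What is called first, only, known or untested is meant among the compounds shown, and "the series" means these compounds.

Compound 1 `O=C1/C(=C\c2cccc(Br)c2)c2ccccc2N1c1c(Cl)cccc1Cl` is the anchor of the set. In a functional assay on MOLT-4 cells (Homo sapiens) for cytotoxicity, read by MTT assay, with a stated time of 72 h (a lower number here means that less compound is needed, a higher number that more compound is needed for the effect), compound 1 gives 7 ug/mL; this is the only numbered result so far. Compound 2 `Cc1ccc2nc(Cl)c(/C=C3\C(=O)N(c4c(Cl)cccc4Cl)c4ccccc43)cc2c1` belongs to the same series, but in this assay compound 2 shows "not determined" (no result reported), so it offers no number for comparison. Among the compounds with values here, no step between two measured compounds is available, and the scatter of repeated measurements remains the only yardstick.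

Compound 3 `O=C1/C(=C\c2cccc(Cl)c2)c2ccccc2N1c1c(Cl)cccc1Cl` is the next entry for this assay. It differs from compound 1 in one place: chloro in place of bromo on an aromatic carbon. Both halogens sit on the same aromatic carbon of the six-membered aromatic ring of carbon only, meta to a large group. With no measured step of this kind in the set, the expected change a 1.1-fold higher number from compound 1 to compound 3 (0.06 log units; within the scatter) is none beyond the scatter, in either direction. Compound 3 is therefore estimated at 8 ug/mL, with a range from 4 ug/mL to 16 ug/mL.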

Compound 3, concentration for half-maximal effect: 6 ug/mL
Compound 3: middle estimate off by 1.3-fold (0.12 log units), on the high side, and the stated range covers the measured number.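

Within the data shown here, the change from 3-bromophenyl to 3-chlorophenyl provides the first measured step: in this assay it gives a 1.2-fold lower number from compound 1 to compound 3 (0.07 log units; within the scatter) and so leaves the number unchanged within the usual scatter. On this aromatic carbon of the six-membered aromatic ring of carbon only, bromo and chloro are therefore not distinguished by this assay, and either compound can serve as the reference for further changes at this place. Nothing at hand bears on the reason for this result.

Still open, going by these compounds, is whether a group other than a halogen at this place, such as a methoxy group, an amine or a carboxylic acid, would shift the number beyond the scatter. The compounds shown also do not tell whether bromo and chloro would remain equivalent on another carbon of this ring.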